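The compounds below may be only part of what the source reports. "The series", "measured", "known", "first", "only" and "open" are said of these compounds alone.

In a functional assay on HepG2 cells (Homo sapiens) for cytotoxicity, with a stated time of 72 h (on this read-out lower numbers stand for an effect already at smaller amounts and higher numbers for an effect only at larger amounts of compound), compound 1 `C=C[C@@](C)(/C=C/c1ccc(O)c(/C=C(\C)C(=O)OCC)c1)CCC=C(C)C` gives > 52000 nM, which is a limit and not a number. Compound 2 `CCOC(=O)/C(C)=C/c1cc(/C=C/[C@](C)(/C=C/c2ccc(OC)cc2)CCC=C(C)C)ccc1O` gives > 52000 nM, again only a limit. Within the data shown here, the series so far therefore stands at the limit of > 52000 nM in this assay, at which 2 of the 2 values shown sit. Among the measured compounds shown here, the one measured step is a step that the two limits leave unreadable from compound 1 to compound 2, and it lies elsewhere in the molecule and offers no size to carry over. Compound 3 `COc1ccc(/C=C/[C@@](C)(/C=C/c2ccc(O)c(/C=C/C(C)=O)c2)CCC=C(C)C)cc1` keeps the 2-(4-methoxyphenyl)ethenyl group of compound 2 and changes the other side: 2-acetylethenyl in place of 2-(ethoxycarbonyl)prop-1-en-1-yl on an aromatic carbon. In words, 2-acetylethenyl replaces 2-(ethoxycarbonyl)prop-1-en-1-yl on an aromatic carbon. With no readable step to guide it, no large shift is expected in this assay, and a reported number could only lie toward smaller amounts than the limit of compound 2. For compound 3 the estimated value is 45000 nM, within an expected range of 15000 nM to 60000 nM. The step expected is an at least 1.1-fold lower number from compound 2 to compound 3 (0.06 log units; that floor lies within the scatter).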

Compound 3, half-maximal effective concentration: > 52000 nM
Compound 3 ended at the assay's limit (the forecaster's own chance of this, stated with the estimate: 65%); middle value at least 1.1-fold (0.06 log units) from the limit.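

Compound 2 and compound 3 both end at a limit of the assay and not at a number, so no step can be read between them: the limit of > 52000 nM in this assay, at which 3 of the 3 values shown sit. The compounds shown leave open whether any of them reaches a measurable value in this assay.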